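Swapping methyl for trifluoromethyl on compound 2

The source may report more compounds than this note shows. Statements on the series, on what has been measured and on what is new or still open speak of the compounds shown alone.

- Compound 1 `CCc1ccccc1NC(=O)[C@@H]1CCCN1S(=O)(=O)c1cccc2cccnc12`: > 50000 nM (a limit of the assay, not a number)
- Compound 2 `Cc1ccc(C)c(NC(=O)[C@@H]2CCCN2S(=O)(=O)c2cccc3cccnc23)c1`: 30900 nM

Going by the values given here, in an ADME assay on HEp-2 cells (Homo sapiens) for cytotoxicity (a lower number here means that less compound is tolerated, a higher number that more compound is tolerated), compound 2 gives 30900 nM, the only true number so far. Compound 1 gives > 50000 nM, which is a limit. The next compound to be measured is compound 3 `Cc1ccc(C(F)(F)F)cc1NC(=O)[C@@H]1CCCN1S(=O)(=O)c1cccc2cccnc12`, which differs from compound 2 by trifluoromethyl in place of methyl on an aromatic carbon.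

Among the compounds with values here, only one measured step can serve as a guide, and it involves different groups: an at least 1.6-fold lower number from compound 1 to compound 2 (0.20 log units; that floor lies within the scatter). Its size is only a floor because of the limit of > 50000 nM in this assay, at which 1 of the 2 values shown sits. Within the data shown here, no measurement yet tests this exact swap, so the guide is weak. With a single step that does not go beyond the scatter, no change beyond the scatter is expected in this assay, and no direction is favoured. The expected change is a 1.0-fold lower number from compound 2 to compound 3 (0.01 log units; within the scatter). For compound 3 the estimated value is 30000 nM, with an expected range from 13000 nM to 50000 nM.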

Compound 3, half-maximal cytotoxic concentration: 4800 nM
For compound 3 the middle estimate is 6.3-fold (0.80 log units) above the measured one; measured number below the stated range.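

In this assay, trifluoromethyl in place of methyl on this aromatic carbon, which is meta to a large group and para to a methyl group, gives a 6.4-fold lower number from compound 2 to compound 3 (0.81 log units; beyond the scatter). So this carbon is not indifferent to what it carries: a change of one small group here is enough to shift the tolerated concentration clearly, and this is the first step among the compounds shown to go beyond the usual scatter. The only earlier step, an at least 1.6-fold lower number from compound 1 to compound 2 (0.20 log units; that floor lies within the scatter), involved different groups and gave no full size, only a floor, for this reason: the limit of > 50000 nM in this assay, at which 1 of the 3 values shown sits.

Going by these compounds, what stays open is whether the lower number follows from the fluorine atoms themselves or simply from a group of more heavy atoms on this carbon, and a single swap cannot separate the two. Whether a hydrogen, a chlorine atom or an ethyl group here would land near compound 2 or near compound 3 is also unknown, as is whether the same swap would give a similar step on another carbon of this ring.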